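Ethyl Against Allyl on a Low-Activity Benzyl Ether Core

The source may hold more compounds than are shown below. What is called first, only, known or untested is meant among the compounds shown, and "the series" means these compounds.

Compound 1 `CCc1cc(C(C)=O)c(O)cc1OCCCCCCC#N` and compound 2 `C=CCc1cc(C(C)=O)c(O)cc1OCCCCCCC#N` share a core and differ in one place, described as methyl in place of vinyl on a saturated chain carbon bound to an aromatic carbon; in an assay on isolated protein for inhibition of leukotriene B4 receptor 1 (Homo sapiens), tested at 10 uM (a higher number here means more inhibition at the concentration tested (going by the name of the read-out), a lower number less inhibition), compound 1 gives 103%, and compound 2 gives 97%, so the step of a number 6 percentage points higher from compound 2 to compound 1 (within the scatter). Compound 3 `C=CCc1cc(C(C)=O)c(O)cc1OCc1ccc(C#N)cc1` carries a different core, and the difference between its core and that of compound 2 is not broken down here; in this assay compound 3 gives 22%. Compound 4 `CCc1cc(C(C)=O)c(O)cc1OCc1ccc(C#N)cc1` has not yet been measured; it stands to compound 3 as compound 1 stands to compound 2, the change being (methyl in place of vinyl on a saturated chain carbon bound to an aromatic carbon). Because the earlier step of a number 6 percentage points higher from compound 2 to compound 1 (within the scatter) lay within the scatter, the expected step is a number 6 percentage points higher from compound 3 to compound 4 (within the scatter). In this assay compound 4 is estimated at 28%, expected to fall between 10% and 46%.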

Compound 4, a percentage reported as inhibition, at one concentration (the size of the read-out at that concentration, not a potency): 7%
Beside the measured number, compound 4's estimate is 21 percentage points above it; the measured number lies below the stated range.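

On the core of compound 3, the change from allyl to ethyl gives a number 15 percentage points lower from compound 3 to compound 4 (beyond the scatter) in this assay. The change therefore does not carry over as a constant step between the two cores in this assay: the same change on two cores in this assay, a number 6 percentage points higher (within the scatter) from compound 2 to compound 1 and a number 15 percentage points lower (beyond the scatter) from compound 3 to compound 4, 21 percentage points apart, beyond the scatter of two such steps. Going by these compounds alone, this rests on only two pairs, and it shows neither what sets the two cores apart nor how the change would read on any other core.

The compounds shown leave open whether propyl in place of ethyl would follow the same course on each core. They also leave open how the change from allyl to ethyl would read with a carboxylic acid or an amine in place of the nitrile.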